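The source may report more compounds than this note shows. Statements on the series, on what has been measured and on what is new or still open speak of the compounds shown alone.

Measured compounds:
Compound 1, `CC(=O)N1N=C(c2ccc(-n3c(C)ccc3C)cc2)OC1c1ccccc1Cl`, gives 206000 nM in an ADME assay on A549 cells (Homo sapiens) for cytotoxicity, read by MTT assay, with a stated time of 72 h; a lower number here means a stronger inhibitor, a higher number a weaker inhibitor.
Compound 2, `O=C(NNC(=O)c1ccc(F)c(C(F)(F)F)c1)c1ccc(-n2cccc2)cc1`, gives 200000 nM in this assay.

The two measured compounds share a para-substituted phenyl carrying a pyrrole nitrogen, but their cores differ. In this assay compound 1 gives 206000 nM and compound 2 gives 200000 nM; the two numbers lie within the scatter of each other, so neither compound can be called the stronger or weaker inhibitor, and both sit at the weak end of what this read-out resolves.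

Compound 3, `CC(=O)N1N=C(c2ccc(-n3c(C)ccc3C)cc2)OC1c1cccc([N+](=O)[O-])c1`, keeps the core of compound 1 and changes one group: 3-nitrophenyl in place of 2-chlorophenyl on a saturated ring carbon. Among the compounds with values here, no measured pair shows what this exchange does to the cytotoxicity read-out, so the expectation rests on compound 1 alone, whose value of 206000 nM is already very weak. The step from compound 1 to compound 3 is expected to be a 1.0-fold lower number from compound 1 to compound 3 (0.01 log units; within the scatter), that is, no change beyond the scatter in either direction. Compound 3 is therefore estimated at 200000 nM, with a range from 100000 nM to 400000 nM.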

Compound 3, half-maximal inhibitory concentration: 197000 nM
Beside the measured number, compound 3's estimate is 1.0-fold (0.01 log units) above it; measured number inside the range.
By their numbers in this assay, from the lowest: compounds 3, 2 and 1 (each within the scatter of the next).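

With compound 3, the saturated ring carbon in the core of compound 1 has its first measured exchange, and in this assay the step is a 1.0-fold lower number from compound 1 to compound 3 (0.02 log units; within the scatter). The earlier compounds shown here formed no pair differing in one place, so they could not show that 3-nitrophenyl, with 2 hydrogen-bond acceptors against 0 for 2-chlorophenyl, can take the place of 2-chlorophenyl on this carbon while the read-out fails to separate the two compounds. No measurement at hand bears on the reason for this result.

The exchange alters both the substituent and its place on the phenyl ring, so a pair with 3-chlorophenyl or 2-nitrophenyl on this carbon would be needed to tell these two parts apart. Also open, from the compounds shown here alone, is whether the read-out would stay in the same range with a phenyl ring carrying an amine or a carboxylic acid on this carbon, or with a longer alkyl chain there in place of the phenyl ring.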